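Swapping the Benzyl Substituent: Expected Microsomal Half-Life

The source may hold more compounds than are shown below. What is called first, only, known or untested is meant among the compounds shown, and "the series" means these compounds.

Three compounds share one core and differ only in the group on a saturated chain carbon bound to a sulfur. In an ADME assay on microsomes from liver (Homo sapiens) for metabolic stability, read by LC-MS, using NADPH, tested at 5 uM (a higher number here means that the compound lasts longer, a lower number that the compound disappears faster), compound 1 `Cc1cc(S(=O)(=O)/N=C(\N)n2nccc2-c2ccccc2)c(SCc2ccc(Cl)cc2)cc1Cl` gives 0.34 h, compound 2 `Cc1cc(-c2ccccc2)n(/C(N)=N/S(=O)(=O)c2cc(C)c(Cl)cc2SCc2ccccc2C(F)(F)F)n1` gives 0.306 h, and compound 3 `Cc1cc(-c2ccccc2)n(/C(N)=N/S(=O)(=O)c2cc(C)c(Cl)cc2SCc2cccc(Cl)c2)n1` gives 0.205 h. Compound 1 holds the highest of the three numbers, yet its gaps to both others lie within the scatter. For the measured compounds named here, the single step at this place, a 1.5-fold lower number from compound 2 to compound 3 (0.17 log units; within the scatter), also stays within the scatter. Compound 4 `Cc1cc(S(=O)(=O)/N=C(\N)n2nccc2-c2ccccc2)c(SCc2cccc(C(F)(F)F)c2)cc1Cl` differs from compound 1 by 3-(trifluoromethyl)phenyl in place of 4-chlorophenyl on a saturated chain carbon bound to a sulfur. Going by the values given here, with only that one comparable step to go by, the expected step in this assay is a 1.1-fold lower number from compound 1 to compound 4 (0.05 log units; within the scatter), none beyond the scatter. Compound 4 is therefore estimated at 0.3 h, within a range from 0.15 h to 0.6 h.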

Compound 4, half-life: 0.0863 h
Estimate against measurement, compound 4: 3.5-fold (0.54 log units) above; measured number outside the range, below it.
By their numbers in this assay, from the lowest: compound 4; then compounds 3, 2 and 1 (each within the scatter of the next).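

In this assay, the place on a saturated chain carbon bound to a sulfur now gives a step beyond the scatter: a 3.9-fold lower number from compound 1 to compound 4 (0.60 log units; beyond the scatter), with 3-(trifluoromethyl)phenyl in place of 4-chlorophenyl. For the compounds shown here, the earlier compounds showed only gaps within the scatter, so this is the first sign that the group here can change how long a compound lasts. Nothing available explains this step.

Going by these compounds, whether the same swap has the same effect on the core of compound 2 remains open. So does the effect of a phenyl group carrying an amine or a carboxylic acid at this place.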